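Cytotoxicity of biphenylsulfonamides: a single aryl swap

The source may report more compounds than this note shows. Statements on the series, on what has been measured and on what is new or still open speak of the compounds shown alone.

Measured so far:
Compound 1 `O=S(=O)(Nc1cccc(CO)c1)c1ccc(-c2ccccc2)cc1` gives 2200 nM in a functional assay on J774 cells (Mus musculus) for cytotoxicity, read by resazurin assay, with a stated time of 72 h; a lower number here means a stronger inhibitor, a higher number a weaker inhibitor.
Compound 2 `O=S(=O)(Nc1cccc(CO)c1)c1ccc(-c2ccc(Cl)cc2)cc1` gives 2500 nM in this assay.

Among the compounds with values here, compound 2 holds the higher of the two numbers, but its only neighbour is compound 1, and the step of a 1.1-fold higher number from compound 1 to compound 2 (0.06 log units; within the scatter) is within the scatter, so the two compounds cannot be told apart on these numbers.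

Compound 3 `O=S(=O)(Nc1cccc(CO)c1)c1ccc(-c2ccccc2F)cc1` has not yet been measured. Its change from compound 2 is 2-fluorophenyl in place of 4-chlorophenyl on an aromatic carbon. Within the data shown here, the only measured step that bears on it is the one from compound 1 to compound 2, which added chloro and changed nothing beyond the scatter. Removing that chloro again and placing fluoro elsewhere on the entering 2-fluorophenyl is therefore expected to move the number little, with no direction predicted beyond the scatter; the expected step is a 1.1-fold lower number from compound 2 to compound 3 (0.04 log units; within the scatter).

Compound 3 is estimated at 2300 nM, with a likely range from 1000 nM to 5500 nM.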

Compound 3, half-maximal inhibitory concentration: 1300 nM
Beside the measured number, compound 3's estimate is 1.8-fold (0.25 log units) above it; the range from low to high includes it.
By their numbers in this assay, from the lowest: compounds 3, 1 and 2 (each within the scatter of the next).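

In this assay, the exchange of 4-chlorophenyl for 2-fluorophenyl gives a 1.9-fold lower number from compound 2 to compound 3 (0.28 log units; within the scatter), and fluoro in place of hydrogen gives a 1.7-fold lower number from compound 1 to compound 3 (0.23 log units; within the scatter). The earlier pair tested only a chloro substituent, whereas these steps add a different halogen at a different ring carbon, and neither step lies beyond the scatter. Compounds 1, 2 and 3 therefore cannot be told apart in this cytotoxicity measure, and nothing available explains the small differences in their numbers.

Because the step from compound 2 to compound 3 changes both the halogen and its ring carbon, the compounds shown cannot separate those two changes. Going by these compounds, it also remains open whether an amine or a carboxylic acid on this phenyl group would move the number beyond the scatter.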